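Replacing the 4-aminobutyl chain of compound 1 with methyl

The source may hold more compounds than are shown below. What is called first, only, known or untested is meant among the compounds shown, and "the series" means these compounds.

Compound 1 `NCCCCN(C[C@H]1Cc2ncccc2CN1)[C@H]1CCCc2cccnc21`: 64%
Compound 2 `NCCCCN(C[C@@H]1Cc2ncccc2CN1)[C@H]1CCCc2cccnc21`: 55%

In an ADME assay on microsomes from liver (Rattus norvegicus) for metabolic stability, using NADPH, with a stated time of 10 min (a lower number here means that less of the compound is left, a higher number that more of the compound is left), compound 1 gives 64%, which lies within the scatter of compound 2. Within the data shown here, the one measured step is a number 9 percentage points lower from compound 1 to compound 2 (within the scatter), and it reflects (the fact that compounds 1 and 2 differ only in the configuration as drawn).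

Compound 3 `CN(C[C@H]1Cc2ncccc2CN1)[C@H]1CCCc2cccnc21` differs from compound 1 by hydrogen in place of 3-aminopropyl on a saturated chain carbon bound to an amine nitrogen, which also reads as 4-aminobutyl to methyl. This change lies in the chain and not in the configuration, so the measured step bears on it only loosely. No step beyond the scatter is expected in this assay, with compound 1 at 64% as the starting point and a wide margin left open. The estimated step is a number 4 percentage points lower from compound 1 to compound 3 (within the scatter). Compound 3 is expected at 60%, with an estimated range from 38% to 80%.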

Compound 3, percent of the compound remaining: 7%
Estimate against measurement, compound 3: 53 percentage points above; the whole stated range lies above it.
By their numbers in this assay, from the lowest: compound 3; then compounds 2 and 1 (each within the scatter of the next).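

In this assay, the change from 4-aminobutyl to methyl gives a number 57 percentage points lower from compound 1 to compound 3 (beyond the scatter). The earlier compounds shown here showed only a number 9 percentage points lower from compound 1 to compound 2 (within the scatter), so they gave no sign that the amount of compound left depends strongly on what stands at this place, on a saturated chain carbon bound to an amine nitrogen. The data shown offer no explanation for the size of this step.

On these data alone, what stays open is whether the step follows the terminal amine, the length of the chain, or both, since the two change together between compound 1 and compound 3. A plain butyl chain would bear on the amine, a 2-aminoethyl chain on the length, and a chain ending in a carboxylic acid on the nature of the end group.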